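The source may hold more compounds than are shown below. What is called first, only, known or untested is meant among the compounds shown, and "the series" means these compounds.

Measured so far, in a functional assay on PANC-1 cells (Homo sapiens) for inhibition, read by MTT assay, with a stated time of 24 h, tested at 10 uM; on this read-out higher numbers stand for more inhibition at the one concentration tested (going by the name of the read-out) and lower numbers for less inhibition:
- compound 1 `CC(C)=CCC1Cc2c(O)cc(=O)n(CCCO)c2CC1(C)C`: 0%
- compound 2 `COc1ccc(NC(=O)Oc2cc(=O)n(CCCO)c3c2CC(CC=C(C)C)C(C)(C)C3)cc1`: 0%

Compound 2 stands level with compound 1 at the digits shown; the one measured step, no change at the digits printed from compound 1 to compound 2 (within the scatter), lies within the scatter, so nothing in the series has yet separated two compounds in this assay.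

Compound 3 `CC(C)=CCC1Cc2c(OC(=O)Nc3ccc(F)cc3)cc(=O)n(CCCO)c2CC1(C)C` differs from compound 2 in one place: fluoro in place of methoxy on an aromatic carbon. Among the measured compounds shown here, no measured step bears directly on this change: the only step in hand concerns (4-methoxyphenyl)carbamoyl in place of hydrogen on an oxygen on an aromatic ring, and it was within the scatter. With the carbamate already in place in compound 2 and no movement anywhere in the series, no step beyond the scatter is expected in this assay for compound 3. The expected step is no change at the digits printed from compound 2 to compound 3 (within the scatter). Compound 3 is accordingly estimated at 0%, with a range from -10% to 10%.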

Compound 3, a percentage reported as inhibition, at one concentration (the size of the read-out at that concentration, not a potency): 0%
The estimate for compound 3 equals the measured number at the digits printed, within the range that was stated.
By their numbers in this assay, from the lowest: compounds 1, 2 and 3 (each within the scatter of the next).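

On the aromatic carbon para to a large group, fluoro in place of methoxy gives no change at the digits printed from compound 2 to compound 3 (within the scatter) in this assay, so this position has now been varied once without separating the two compounds. With (4-fluorophenyl)carbamoyl in place of hydrogen on the oxygen, the step reads no change at the digits printed from compound 1 to compound 3 (within the scatter), so a second carbamoyl group also leaves the read-out undifferentiated from the parent compound. No supporting evidence bears on this result.

From the compounds shown here alone, it remains open whether an amine or a carboxylic acid on the phenyl ring, or a longer chain in place of the hydroxyl-bearing chain on the ring nitrogen, would move this read-out. These compounds also leave open whether any of the three would separate at another concentration.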